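This account rests on a few compounds, and the source may have more. Where it says the series, first, only, none or still open, it means among the compounds named here.

Working notes on the series. In a functional assay, with a stated time of 30 min (a lower number here means a stronger inhibitor, a higher number a weaker inhibitor), compound 1 `CCCCOc1cc(OC)c(Br)cc1C(C)=O` gives 42300000 nM. Compound 2 `CCCCCCCCCCOc1cc(OC)c(Br)cc1C(C)=O` gives 35100000 nM, which lies within the scatter of compound 1, so the two numbers cannot be told apart.

Compound 3 `CCCCCCCCCCCCOc1cc(OC)c(Br)cc1C(C)=O` lengthens the chain of compound 2: ethyl in place of hydrogen on a saturated chain carbon, ten or more bonds along the chain from an oxygen on an aromatic ring. The change is ethyl in place of hydrogen on a saturated chain carbon.

For the measured compounds named here, one measured step bears on this: a 1.2-fold lower number from compound 1 to compound 2 (0.08 log units; within the scatter), hexyl in place of hydrogen on the same chain, and it stays within the scatter. A single step is thin support, and the data do not show how a still longer chain behaves in this assay. On this evidence, no step beyond the scatter is expected. The expected change is a 1.1-fold lower number from compound 2 to compound 3 (0.04 log units; within the scatter). For compound 3 the estimate is 32000000 nM, with an expected range from 14000000 nM to 70000000 nM.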

Compound 3, half-maximal inhibitory concentration: 29500000 nM
Estimate against measurement, compound 3: 1.1-fold (0.04 log units) above, and the stated range covers the measured number.
By their numbers in this assay, from the lowest: compounds 3, 2 and 1 (each within the scatter of the next).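

In this assay the ethyl extension gives a 1.2-fold lower number from compound 2 to compound 3 (0.08 log units; within the scatter) and stays within the scatter, so the flat reading now holds for a second change on this chain. The widest span shown, octyl in place of hydrogen, gives a 1.4-fold lower number from compound 1 to compound 3 (0.16 log units; within the scatter) and also stays within the scatter, so all three compounds remain indistinguishable, with none going against this reading. No measurement available here accounts for this lack of separation among the three chain lengths.

Going by these compounds, whether a longer chain, or a chain ending in an amine or a carboxylic acid, would separate from these three numbers stays open. The compounds shown also leave open whether a change elsewhere on the shared core, such as a hydroxyl group in place of the bromine, would move the number beyond the scatter.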